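Swapping a tert-butyl for a nitro on a weakly active pair

The source may hold more compounds than are shown below. What is called first, only, known or untested is meant among the compounds shown, and "the series" means these compounds.

Measured compounds:
- Compound 1, `O=c1ccoc2cc(OCc3cn(Cc4cccc([N+](=O)[O-])c4)nn3)ccc12`: > 100000 nM
- Compound 2, `CC(C)(C)c1ccc(Cn2cc(COc3ccc4c(=O)ccoc4c3)nn2)cc1`: > 100000 nM

Both compounds were tested in a functional assay on SGC-7901 cells (Homo sapiens) for cytotoxicity, read by MTT assay, with a stated time of 48 h; a lower number here means a stronger inhibitor, a higher number a weaker inhibitor. Compound 1 gives > 100000 nM, which is a limit of the assay rather than a number. Compound 2 likewise gives > 100000 nM, again a limit and not a measured number. So compound 2 stands at the ceiling of what the assay reports, and it shares that position with compound 1, as shown by the limit of > 100000 nM in this assay, at which 2 of the 2 values shown sit. Within the data shown here, no step between the two can be sized.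

Compound 3, `O=c1ccoc2cc(OCc3cn(Cc4ccc([N+](=O)[O-])cc4)nn3)ccc12`, has not yet been tested. Compared with compound 2, the change is nitro in place of tert-butyl on an aromatic carbon, a nitro in place of tert-butyl on an aromatic carbon, para to a large group. Among the measured compounds shown here, with both neighbours sitting at the limit, there is no measured step to lean on. The step from compound 2 to compound 3 is expected to be a step that the limit leaves unreadable from compound 2 to compound 3, which is none beyond the scatter. Compound 3 is therefore estimated at 200000 nM, within a range from 60000 nM to 1000000 nM, with a strong chance that the assay again returns only a limit.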

Compound 3, half-maximal inhibitory concentration: > 100000 nM
Compound 3 gave a limit, no number; the forecaster's own chance of this, stated with the estimate: 85%; the middle value lies beyond the limit too.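

No step can be read from compound 2 to compound 3 or from compound 1 to compound 3, because all three compounds give a limit and not a number: the limit of > 100000 nM in this assay, at which 3 of the 3 values shown sit.

The compounds shown leave open whether nitro and tert-butyl, or 4-nitrophenyl and 3-nitrophenyl, differ at all in this assay.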